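This account rests on a few compounds, and the source may have more. Where it says the series, first, only, none or still open, it means among the compounds named here.

Measured compounds:
compound 1 `COc1cc(/C=C/C(=O)/C=C(/C=C/c2ccc(OC(C)=O)c(OC)c2)NC2CCCCC2)ccc1OC(C)=O`, > 25000 nM
compound 2 `COc1cc(/C=C/C(=O)/C=C(/C=C/c2ccc(OC(C)=O)c(OC)c2)NCC(C)C)ccc1OC(C)=O`, > 25000 nM
compound 3 `COc1cc(/C=C/C(=O)/C=C(/C=C/c2ccc(O)c(OC)c2)NC2CCCCC2)ccc1O`, > 25000 nM

In an ADME assay on EA.hy 926 cells (Homo sapiens) for inhibition, read by sulforhodamine B assay, with a stated time of 72 h (a higher number here means a weaker inhibitor, a lower number a stronger inhibitor), compound 1 gives only a limit of the assay, > 25000 nM. Compound 2 likewise gives only a limit, > 25000 nM. Compound 3 also gives only a limit, > 25000 nM. The change from compound 1 to compound 2 is isobutyl in place of cyclohexyl on an amine nitrogen; the step that the two limits leave unreadable from compound 1 to compound 2 cannot be read because of the limit of > 25000 nM in this assay, at which 3 of the 3 values shown sit. Compound 4 `COc1cc(/C=C/C(=O)/C=C(/C=C/c2ccc(O)c(OC)c2)NCC(C)C)ccc1O` carries the same change on the core of compound 3: isobutyl in place of cyclohexyl on an amine nitrogen. The difference between the two cores is not broken down here. Because (the limit of > 25000 nM in this assay, at which 3 of the 3 values shown sit), no size can be taken from the earlier step, and compound 4 is expected to remain at the limit as well, an expected step that the limit leaves unreadable from compound 3 to compound 4. The estimate for compound 4 in this assay is therefore 40000 nM.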

Compound 4, half-maximal inhibitory concentration: > 25000 nM
Compound 4 was reported as a limit (the forecaster's own chance of this, stated with the estimate: 85%); the middle value does not contradict the limit.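

No size can be read for the change from cyclohexyl to isobutyl between compound 3 and compound 4, for one reason: the limit of > 25000 nM in this assay, at which 4 of the 4 values shown sit. The compounds shown leave open whether either this change or the difference between the two cores alters inhibition in this assay.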